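A few compounds are considered here, and "the series" means these few. Any claim that something is new, unique, unknown or untested is made for them only; others in the source may bear on it.

Values in a functional assay on MKN-45 cells (Homo sapiens) for cytotoxicity, read by MTT assay, with a stated time of 72 h (on this read-out higher numbers stand for weaker inhibition and lower numbers for stronger inhibition), so far:

compound 1, `COc1cc2c(Oc3ccc(NC(=O)c4cn(-c5cc(C)ccc5C)cn4)cc3F)ccnc2cc1OCCCN1CCN(C)CC1`: 650 nM
compound 2, `COc1cc2c(Oc3ccc(NC(=O)c4cn(-c5cc(C)ccc5C)cn4)cc3F)ccnc2cc1OCCCN1CCC(C)CC1`: 5650 nM
compound 3, `COc1cc2c(Oc3ccc(NC(=O)/C=C/S(=O)(=O)c4ccccc4F)cc3F)ccnc2cc1OCCCN1CCN(C)CC1`: 280 nM

Within the core of compound 1, the change 4-methylpiperidin-1-yl in place of 4-methylpiperazin-1-yl on a saturated chain carbon, three bonds along the chain from an oxygen on an aromatic ring produces an 8.7-fold higher number from compound 1 to compound 2 (0.94 log units; beyond the scatter). Compound 3 is built on a different core; the difference between the two cores is not broken down here. On the numbers alone, compound 3 gives the lowest value of the three, with compound 1 nearest and compound 2 furthest.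

Compound 4, `COc1cc2c(Oc3ccc(NC(=O)/C=C/S(=O)(=O)c4ccccc4F)cc3F)ccnc2cc1OCCCN1CCC(C)CC1`, is not yet measured in this assay. From compound 3 it differs by 4-methylpiperidin-1-yl in place of 4-methylpiperazin-1-yl on a saturated chain carbon, three bonds along the chain from an oxygen on an aromatic ring, the same change as that from compound 1 to compound 2, at the same place. Within the data shown here, the step is estimated at an 8.6-fold higher number from compound 3 to compound 4 (0.93 log units; beyond the scatter), expected to run alongside the earlier one, because the only precedent for this change is an 8.7-fold higher number from compound 1 to compound 2 (0.94 log units; beyond the scatter). The estimate rests on a single pair and on a different core, so the range is kept wide. Compound 4 is expected to give about 2400 nM in this assay, with a range from 900 nM to 6500 nM.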

Compound 4, half-maximal inhibitory concentration: 840 nM
Compound 4: the middle estimate sits 2.9-fold (0.46 log units) above what was measured; measured number below the stated range.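

In this assay, 4-methylpiperidin-1-yl in place of 4-methylpiperazin-1-yl again raises the number on the core of compound 3, giving a 3.0-fold higher number from compound 3 to compound 4 (0.48 log units; beyond the scatter). The direction of the change therefore holds on both cores, but its size does not carry over unchanged: the same change on two cores in this assay, an 8.7-fold higher number (0.94 log units; beyond the scatter) from compound 1 to compound 2 and a 3.0-fold higher number (0.48 log units; beyond the scatter) from compound 3 to compound 4, 2.9-fold (0.46 log units) apart, beyond the scatter of two such steps Two pairs show only that the size of this step can depend on the core; they do not show which part of the core matters, why the steps differ, or how large the step would be on any further core.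

Still open, on these data alone, is how other amines at the end of the propyl chain, such as a morpholine or a dimethylamine, or a longer chain carrying the same two rings, would read in this assay. A third core, for example one with a plain benzamide as its amide part, would show whether either of the two step sizes is typical of the series.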